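The source may report more compounds than this note shows. Statements on the series, on what has been measured and on what is new or still open speak of the compounds shown alone.

Working notes on the series. Among the measured compounds shown here, in a functional assay on HT-29 cells (Homo sapiens) for cytotoxicity, read by MTT assay, with a stated time of 72 h (on this read-out higher numbers stand for weaker inhibition and lower numbers for stronger inhibition), compound 1 (`O=C(CN1CCN(c2nnc(Cc3ccccc3)c3ccccc23)CC1)Nc1ccc(F)c(C(F)(F)F)c1`) gives 4590 nM, the highest of the three numbers so far. Compound 2 (`O=C(CN1CCN(c2nnc(Cc3ccncc3)c3ccccc23)CC1)Nc1ccc(F)c(C(F)(F)F)c1`) gives 1110 nM and compound 3 (`Cc1ccc(F)cc1NC(=O)CN1CCN(c2nnc(Cc3ccncc3)c3ccccc23)CC1`) gives 470 nM in the same assay.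

Compound 4 (`O=C(CN1CCN(c2nnc(Cc3ccccc3)c3ccccc23)CC1)Nc1ccc(Br)cc1`) is still unmeasured. It keeps the core of compound 1 and carries 4-bromophenyl in place of 4-fluoro-3-(trifluoromethyl)phenyl on an amide-type nitrogen.

For the measured compounds named here, only one measured step touches this place. Putting 5-fluoro-2-methylphenyl in place of 4-fluoro-3-(trifluoromethyl)phenyl gave a 2.4-fold lower number from compound 2 to compound 3 (0.37 log units; beyond the scatter) as a modest change. That step has a different entering group and a pyridin-4-yl in the other arm, so it is only a loose guide. The other measured step, a 4.1-fold lower number from compound 1 to compound 2 (0.62 log units; beyond the scatter) at the far end of the molecule, leaves this place untouched and shows only that modest moves are what the series has produced so far. Going by the values given here, no measured compound carries 4-bromophenyl.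

A small shift toward a lower number is therefore expected, possibly none beyond the scatter, and the estimated step is a 1.5-fold lower number from compound 1 to compound 4 (0.18 log units; within the scatter) in this assay. For compound 4 the expected value is 3000 nM (1000 nM to 9000 nM).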

Compound 4, half-maximal inhibitory concentration: 60200 nM
Compound 4: middle estimate off by 20-fold (1.30 log units), on the low side, and the stated range ends below it.
By their numbers in this assay, from the lowest: compound 3; then compound 2; then compound 1; then compound 4.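

In this assay, among the compounds shown here, the place on the amide-type nitrogen proves far more sensitive than the earlier compounds suggested: 4-bromophenyl in place of 4-fluoro-3-(trifluoromethyl)phenyl gives a 13-fold higher number from compound 1 to compound 4 (1.12 log units; beyond the scatter), the largest step and the only one toward a higher number. For the compounds shown here, the one earlier change at this place, a 2.4-fold lower number from compound 2 to compound 3 (0.37 log units; beyond the scatter), ran the other way, so replacing 4-fluoro-3-(trifluoromethyl)phenyl can move the number in either direction, although those two steps differ both in the entering group and in the arm at the far end of the molecule. Nothing available here accounts for the size of the rise.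

The compounds shown leave open whether 4-bromophenyl produces a similar rise when the far arm carries pyridin-4-yl instead of phenyl, as in compound 2, or whether that arm alters the outcome at this place. They also leave open how an unsubstituted phenyl on the same nitrogen would stand, and whether chlorine in place of the bromine would give a comparable number, which would help separate the effect of the bromine from that of losing the fluorine and trifluoromethyl groups.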